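The source may hold more compounds than are shown below. What is called first, only, known or untested is meant among the compounds shown, and "the series" means these compounds.

Compound 1 `COc1ccccc1Cn1ccc2nc(-c3ccccc3)nc-2c1` — > 100000 nM, which is a limit of the test.
Compound 2 `COc1ccc(Cn2ccc3nc(-c4ccccc4)nc-3c2)cc1` — > 100000 nM, likewise a limit.
Compound 3 `Clc1ccc(Cn2ccc3nc(-c4ccccc4)nc-3c2)cc1Cl` — 71000 nM.

In an ADME assay on MDBK cells (Bos taurus) for cytotoxicity (on this read-out lower numbers stand for higher toxicity in this test and higher numbers for lower toxicity in this test), compound 3 stands as the only number shown; the other two values sit at a limit, (the limit of > 100000 nM in this assay, at which 2 of the 3 values shown sit). Compound 4 `Clc1ccc(Cn2ccc3nc(-c4ccccc4)nc-3c2)s1` differs from compound 3 in one place: 5-chlorothiophen-2-yl in place of 3,4-dichlorophenyl on a saturated chain carbon bound to an aromatic nitrogen. The measured steps that bear on it are an at least 1.4-fold lower number from compound 1 to compound 3 (0.14 log units; that floor lies within the scatter) and an at least 1.4-fold lower number from compound 2 to compound 3 (0.14 log units; that floor lies within the scatter), while a step that the two limits leave unreadable from compound 1 to compound 2. Since both steps onto compound 3 are only floors that lie within the scatter, compound 4 is expected to stay close to compound 3, with an estimated step of a 1.3-fold higher number from compound 3 to compound 4 (0.10 log units; within the scatter) that need not exceed the scatter. Compound 4 is therefore estimated at 90000 nM, between 40000 nM and 200000 nM.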

Compound 4, half-maximal cytotoxic concentration: > 100000 nM
Compound 4: only a limit was reported; the forecaster's own chance of this, stated with the estimate: 45%; middle value at least 1.1-fold (0.04 log units) from the limit.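

In this assay compound 4 gives > 100000 nM, which is a limit of the test. At this place, on a saturated chain carbon bound to an aromatic nitrogen, 5-chlorothiophen-2-yl brings in the first five-membered aromatic ring with a hetero atom, and replacing 3,4-dichlorophenyl gives an at least 1.4-fold higher number from compound 3 to compound 4 (0.14 log units; that floor lies within the scatter), so the two groups are not separated. The steps to compound 4 from compound 1 and compound 2 cannot be read, and the limit now holds most of the set: the limit of > 100000 nM in this assay, at which 3 of the 4 values shown sit.

Going by these compounds, it remains open whether an amine or a carboxylic acid at this place would give a readable number in this assay.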